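This account rests on a few compounds, and the source may have more. Where it says the series, first, only, none or still open, it means among the compounds named here.

Compound 1 `CCCCCCc1cn(-c2ccc(O)c(C(=O)NCCC)c2)nn1` carries a propylamino group on its carbonyl carbon. In a functional assay on RAW264.7 cells (Mus musculus) for inhibition, read by Griess assay, with a stated time of 20 h (on this read-out higher numbers stand for weaker inhibition and lower numbers for stronger inhibition), compound 1 gives 19700 nM. Compound 2 `CCCCCCc1cn(-c2ccc(O)c(C(=O)N3CCCCC3)c2)nn1` differs from it only by piperidin-1-yl in place of propylamino on a carbonyl carbon. For compound 2 this assay reports only a limit, > 20000 nM. The change yields an at least 1.0-fold higher number from compound 1 to compound 2 (0.00 log units; that floor lies within the scatter), so the two compounds cannot be separated on this read-out.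

Compound 3 `CCCNC(=O)c1ccc(-n2cc(-c3cc(C(F)(F)F)cc(C(F)(F)F)c3)nn2)cc1O` keeps the propylamino group on its carbonyl carbon but is built on a different core; the difference between the core of compound 1 and the core of compound 3 is not broken down here. For compound 3 this assay again reports only a limit, > 20000 nM.

Compound 4 `O=C(c1ccc(-n2cc(-c3cc(C(F)(F)F)cc(C(F)(F)F)c3)nn2)cc1O)N1CCCCC1` has not yet been measured. It differs from compound 3 by piperidin-1-yl in place of propylamino on a carbonyl carbon, the same change that separates compound 1 from compound 2, made at the same place. Among these compounds (the limit of > 20000 nM in this assay, at which 2 of the 3 values shown sit), which leaves little room to see any effect of the change.

From compound 3 to compound 4 the step is expected to be a step that the limit leaves unreadable from compound 3 to compound 4, because compound 3 already sits at the limit > 20000 nM and because the same change gave an at least 1.0-fold higher number from compound 1 to compound 2 (0.00 log units; that floor lies within the scatter). Compound 4 is therefore estimated to show 35000 nM in this assay, with a plausible range from 15000 nM to 100000 nM, and most likely the assay will again report only a limit.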

Compound 4, half-maximal inhibitory concentration: > 20000 nM
Compound 4 was reported as a limit; the forecaster's own chance of this, stated with the estimate: 85%; the middle value is on the limit's open side.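

In this assay, compound 4 is reported only as a limit, as is compound 3, so no step from compound 3 to compound 4 can be read: the limit of > 20000 nM in this assay, at which 3 of the 4 values shown sit.

The compounds shown leave open whether piperidin-1-yl in place of propylamino on the carbonyl carbon changes inhibition at all, and how strongly compound 2, compound 3 and compound 4 actually inhibit.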